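A few compounds are considered here, and "the series" means these few. Any claim that something is new, unique, unknown or untested is made for them only; others in the source may bear on it.

Compound 1 `NC(=O)c1c(NC(=O)c2ccccc2Br)sc2c1CCN(C(=S)Nc1ccccc1F)C2` carries a bromo group on the benzamide ring and a fluoro group on the thiourea ring. In a functional assay on HL-60 cells (Homo sapiens) for antiproliferative activity, with a stated time of 24 h (on this read-out lower numbers stand for stronger inhibition and higher numbers for weaker inhibition), compound 1 gives only a limit, > 50000 nM, which is where (the limit of > 50000 nM in this assay, at which 1 of the 3 values shown sits). Compound 2 `NC(=O)c1c(NC(=O)c2ccccc2I)sc2c1CCN(C(=S)Nc1ccccc1Br)C2` gives 18900 nM in this assay, and compound 3 `NC(=O)c1c(NC(=O)c2ccccc2I)sc2c1CCN(C(=S)Nc1ccccc1C(F)(F)F)C2` gives 19700 nM. The difference between the core of compound 1 and the core of compound 2 is not broken down here.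

The step from compound 2 to compound 3 is trifluoromethyl in place of bromo on an aromatic carbon, and it made a 1.0-fold higher number from compound 2 to compound 3 (0.02 log units; within the scatter). Compound 4 `NC(=O)c1c(NC(=O)c2ccccc2C(F)(F)F)sc2c1CCN(C(=S)Nc1ccccc1F)C2` is to be measured in this assay; it differs from compound 1 by trifluoromethyl in place of bromo on an aromatic carbon, the same change on the same kind of place. Since compound 2 to compound 3 gave a 1.0-fold higher number from compound 2 to compound 3 (0.02 log units; within the scatter), the step from compound 1 to compound 4 is expected to be similar, a step that the limit leaves unreadable from compound 1 to compound 4, and because compound 1 stands at > 50000 nM the value of compound 4 is expected to be 60000 nM, most likely again a limit, between 25000 nM and 150000 nM.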

Compound 4, half-maximal inhibitory concentration: 23500 nM
The estimate for compound 4 lay 2.6-fold (0.41 log units) above the measured number; measured number below the stated range.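

In this assay, trifluoromethyl in place of bromo on the benzamide ring gave an at least 2.1-fold lower number from compound 1 to compound 4 (0.32 log units; beyond the scatter), while the same swap on the thiourea ring of a different core gave a 1.0-fold higher number from compound 2 to compound 3 (0.02 log units; within the scatter). For compound 1, > 50000 nM is a limit and not a number, so this step has a lower bound but no exact size. The result therefore shows that the swap can go with a lower number on the core of compound 1, but it does not show that the change behaves differently from one core to the other: the same change on two cores in this assay, a 1.0-fold higher number (0.02 log units; within the scatter) from compound 2 to compound 3 and an at least 2.1-fold lower number (0.32 log units; beyond the scatter) from compound 1 to compound 4; the limit leaves it open whether they differ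

The compounds shown carry only halogens and trifluoromethyl on these two rings, which leaves open how an amine, a carboxylic acid or a methoxy group would read there in this assay. As far as these compounds go, with a single pair on each core, it also remains open whether the swap would give a similar step on any further core.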